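A few compounds are considered here, and "the series" means these few. Any claim that something is new, unique, unknown or untested is made for them only; others in the source may bear on it.

Of the compounds shown here, three built on two related cores have been tested in an ADME assay on S9 fraction from liver (Rattus norvegicus) for metabolic stability, read by LC-MS, using NADPH, with a stated time of 30 min; on this read-out lower numbers stand for a less stable compound and higher numbers for a more stable compound. Compound 1, with the structure `CCCCCCCCc1ccc(OCC(=O)Cn2nnc(-c3cccc(Cl)c3)n2)cc1`, gives 69%. Compound 2, with the structure `CCCCCCCCc1ccc(OCC(=O)Cn2nnc(-c3ccccc3Cl)n2)cc1`, carries one change against compound 1: 2-chlorophenyl in place of 3-chlorophenyl on an aromatic carbon. This change brought a number 41 percentage points lower from compound 1 to compound 2 (beyond the scatter). In this assay compound 2 gives 28%. Compound 3, with the structure `CCCCCCCCc1ccc(OCC(=O)Cn2nnnc2-c2cccc(Cl)c2)cc1`, stands on a different core; the difference between the two cores is not broken down here. In this assay compound 3 gives 41%, a lower number than compound 1 and a higher one than compound 2, with both gaps beyond the usual scatter.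

Compound 4, with the structure `CCCCCCCCc1ccc(OCC(=O)Cn2nnnc2-c2ccccc2Cl)cc1`, has not yet been measured. Against compound 3 it shows (2-chlorophenyl in place of 3-chlorophenyl on an aromatic carbon). Among the measured compounds shown here, this is the same kind of change as the one from compound 1 to compound 2, but not the same: in compound 1 the phenyl ring sits two ring bonds from the ring atom that bears a large group, whereas in compound 3 it sits next to the ring atom that bears a large group.

For the measured compounds named here, the one observed example of this change, the step from compound 1 to compound 2, was large and downward, so a fall of similar direction is expected for compound 4, tempered because compound 3 gives 41%, which leaves less room beneath it. The expected step is a number 26 percentage points lower from compound 3 to compound 4 (beyond the scatter). Compound 4 is therefore estimated at 15%, most likely within 3% to 35%.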

Compound 4, percent of the compound remaining: 42%
Estimate against measurement, compound 4: 27 percentage points below, outside the stated range (above it).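

In this assay the swap of 3-chlorophenyl for 2-chlorophenyl on the core of compound 3 gives a number 1 percentage points higher from compound 3 to compound 4 (within the scatter) and so the two compounds cannot be told apart on this read-out. This shows that, for these two pairs, the result of the swap on one core did not predict its result on the other, so the step seen on the core of compound 1 cannot simply be carried across. Among the compounds shown here, with only one pair on each core, the data do not show why the two cores differ or how the swap would behave on a further core, but the gap between the two steps is clear: the same change on two cores in this assay, a number 41 percentage points lower (beyond the scatter) from compound 1 to compound 2 and a number 1 percentage points higher (within the scatter) from compound 3 to compound 4, 42 percentage points apart, beyond the scatter of two such steps.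

All four compounds shown keep an octyl chain and a chlorine on the phenyl ring, so it remains open whether the two cores would still part ways with a fluorine or a methoxy group in place of that chlorine. Going by these compounds, it is also open whether the same holds with a different chain in place of the octyl chain, such as a shorter hexyl chain or a longer decyl chain.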